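Turning One Ring Carbon Over in a Receptor Agonist

A few compounds are considered here, and "the series" means these few. Any claim that something is new, unique, unknown or untested is made for them only; others in the source may bear on it.

Of the compounds shown here, two have been measured so far. Compound 1 `Cc1ccc2[nH]c(C(=O)N[C@H]3CN(S(=O)(=O)c4ccccc4)C[C@@H]3C(=O)NC[C@H]3CCCN3)cc2c1` and compound 2 `Cc1ccc2[nH]c(C(=O)N[C@H]3CN(S(=O)(=O)c4ccccc4)C[C@@H]3C(=O)N[C@@H]3CCCN(C)C3)cc2c1` share the same core and differ only in the group attached to one amide-type nitrogen. In a functional assay on HEK293 cells for agonist activity at growth hormone secretagogue receptor type 1 (Homo sapiens), read by HTRF and inositol phosphate accumulation, with a stated time of 90 min, in the presence of a further agent that is not named here (a higher number here means a larger maximal response, a lower number a smaller maximal response), compound 1 gives 94%, and compound 2 gives 91%. The step of a number 3 percentage points lower from compound 1 to compound 2 (within the scatter) shows that swapping one of these groups for the other left the maximal response essentially unchanged; compound 2 therefore stands alongside compound 1, the two numbers indistinguishable within the usual scatter.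

For the measured compounds named here, compound 3 `Cc1ccc2[nH]c(C(=O)N[C@H]3CN(S(=O)(=O)c4ccccc4)C[C@@H]3C(=O)N[C@H]3CCCN(C)C3)cc2c1` has not yet been measured. the two compounds have the same atoms and bonds and differ only in configuration as drawn: 1 of 3 stereo elements differ; a stereocentre at a saturated ring carbon is drawn R in compound 2 and S in compound 3 No measured step involves a change of configuration alone; the only step so far exchanged one group for another and stayed within the scatter, so it offers no guide to what turning a single ring carbon over will do. With nothing pointing either way, the step of a number 3 percentage points lower from compound 2 to compound 3 (within the scatter) is expected to stay within the scatter, though the range is left wide toward the low side. Compound 3 is therefore estimated at 88%, between 65% and 100%.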

Compound 3, largest response reached (Emax), in percent of the reference or control that the assay uses: 99%
Beside the measured number, compound 3's estimate is 11 percentage points below it; measured number inside the range.
By their numbers in this assay, from the lowest: compounds 2, 1 and 3 (each within the scatter of the next).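

Turning over the stereocentre at a saturated ring carbon gives, in this assay, a number 8 percentage points higher from compound 2 to compound 3 (within the scatter), so at this position the maximal response cannot be shown to depend on whether that carbon is drawn R or S. This is the first comparison that tests configuration alone, and it can be read directly because nothing else separates the pair: the fact that compounds 2 and 3 differ only in the configuration as drawn. The second step, a number 5 percentage points higher from compound 1 to compound 3 (within the scatter), adds that neither drawn form of 1-methylpiperidin-3-yl can be told apart from (pyrrolidin-2-yl)methyl on this amide-type nitrogen.

A maximal response shows how far a compound can drive the receptor, not how much compound is needed to get there, so the two configurations could still differ in the concentration they require. Also open, as far as these compounds go, is whether this insensitivity to configuration would persist with a carboxylic acid or a longer chain in place of the 1-methylpiperidin-3-yl group.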